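Phenyl for Methyl on the Ring Nitrogen of Compound 3

This account rests on a few compounds, and the source may have more. Where it says the series, first, only, none or still open, it means among the compounds named here.

The compounds measured in a functional assay on the whole organism (strain Fischer 344) for inhibition, with Rattus norvegicus as the target, read by paw edema, at a dose of 0.01 mmol/kg by the intraperitoneal route; a lower number here means less inhibition, a higher number more inhibition at the dose given (going by the name of the read-out):
Compound 1 `COC(=O)c1c(O)c2ccccc2n(-c2ccccc2)c1=O` gives 37.1%.
Compound 2 `NCCNC(=O)c1c(O)c2ccccc2n(-c2ccccc2)c1=O` gives 68.1%.
Compound 3 `Cn1c(=O)c(C(=O)NCCCCCCN)c(O)c2ccccc21` gives 68.5%.

Compound 3 and compound 2 sit within the scatter of each other, while compound 1 lies well beyond, lower. Compound 4 `NCCCCCCNC(=O)c1c(O)c2ccccc2n(-c2ccccc2)c1=O` is compound 3 with one change: phenyl in place of methyl on an aromatic nitrogen. Within the data shown here, the only measured step, a number 31 percentage points higher from compound 1 to compound 2 (beyond the scatter), concerns the carbonyl side chain, not the aromatic nitrogen, so it does not bear directly on this change. Compound 2 and compound 3 differ in both the amine-bearing chain and the group on the aromatic nitrogen, yet their values agree within the scatter, which gives no sign that the phenyl matters here. No step beyond the scatter is therefore expected in this assay, with a number 0.5 percentage points lower from compound 3 to compound 4 (within the scatter) as the expected change. Compound 4 is estimated at 68%, from 55% to 80%.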

Compound 4, a percentage reported as inhibition, in the whole organism at one dose (the size of the read-out at that dose, not a potency): 68.8%
Compound 4: the middle estimate sits 0.8 percentage points below what was measured; low and high end bracket the measured number.
By their numbers in this assay, from the lowest: compound 1; then compounds 2, 3 and 4 (each within the scatter of the next).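

In this assay, phenyl in place of methyl on an aromatic nitrogen gives a number 0.3 percentage points higher from compound 3 to compound 4 (within the scatter) and so leaves the read-out unseparated at this dose. With phenyl held in place, the longer chain, 4-aminobutyl in place of amino, gives a number 0.7 percentage points higher from compound 2 to compound 4 (within the scatter) as its step, whereas (6-aminohexyl)amino in place of methoxy gives a number 31.7 percentage points higher from compound 1 to compound 4 (beyond the scatter) as its step, so the large step stays with the carbonyl side chain. Nothing measured here explains these results. Still open, as far as these compounds go, is whether benzyl on the aromatic nitrogen, or a carboxylic acid in place of the chain's amino group, would keep the read-out at this level.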